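This account rests on a few compounds, and the source may have more. Where it says the series, first, only, none or still open, it means among the compounds named here.

Compound 3, with the structure `O=C(O)Cc1sc(C(c2ccc(F)cc2)c2ccc(F)cc2)nc1-c1cc(F)cc(F)c1`, reaches 80% in an in vitro functional assay on HEK285-7 cells for antagonist activity at prostaglandin D2 receptor 2 (Homo sapiens), read by BRET and beta-arrestin recruitment; a higher number here means a larger maximal response, a lower number a smaller maximal response. On that number compound 3 stands level with compound 1, whose structure is `O=C(O)Cc1sc(C(c2ccccc2)c2ccccc2)nc1-c1ccccc1` and which gives 80% in this assay, the two numbers showing no change at the digits reported and lying within the usual scatter. The furthest of the three is compound 2, with the structure `Nc1nc(-c2ccc(Cl)cc2)c(CC(=O)O)s1`, which in this assay gives 50%, a number lower than that of compound 3 and beyond the scatter.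

The next compound, compound 4, has the structure `O=C(O)Cc1sc(C(c2ccc(F)cc2)c2ccc(F)cc2)nc1-c1ccnc(Cl)c1`. It differs from compound 3 in one place: 2-chloropyridin-4-yl in place of 3,5-difluorophenyl on an aromatic carbon. Among the compounds with values here, no pair of the measured compounds differs in a single place, so no comparable step is known. Compound 3 and compound 1 both carry the large group on the shared core and both give the same maximal response, and compound 4 keeps that group. Accordingly the expected step from compound 3 to compound 4, a number 4 percentage points lower from compound 3 to compound 4 (within the scatter), is estimated to stay within the scatter, with no direction claimed. For compound 4 the estimated maximal response in this assay is 76%, in a range from 58% to 92%.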

Compound 4, largest response reached (reported as efficacy), in percent of the reference or control that the assay uses: 80%
The estimate for compound 4 lay 4 percentage points below the measured number, within the range that was stated.
By their numbers in this assay, from the lowest: compound 2; then compounds 1, 3 and 4 (each within the scatter of the next).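

In this assay, 2-chloropyridin-4-yl in place of 3,5-difluorophenyl gives no change at the digits printed from compound 3 to compound 4 (within the scatter). Within the data shown here, this is the first step between compounds that differ in one place, and it shows that at this aromatic carbon of the five-membered ring, a ring with one hetero atom and one hydrogen-bond acceptor can replace a ring of carbon only without the maximal response moving beyond the scatter. Nothing measured here offers an explanation for this result.

As far as these compounds go, it remains open whether this position would keep the same maximal response with a non-aromatic group, such as cyclohexyl or a plain methyl group, in place of the six-membered aromatic ring. Also open, from the compounds shown here alone, is whether a methoxy group could take the place of the chlorine on the pyridine ring with the same outcome.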